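The source may report more compounds than this note shows. Statements on the series, on what has been measured and on what is new or still open speak of the compounds shown alone.

Among the compounds with values here, in an ADME assay (liver) for metabolic stability, with Liver microsome (Homo sapiens) as the target, read by LC-MS, using microsomes and NADPH, with a stated time of 5 min, at 37 degrees C (on this read-out lower numbers stand for slow clearance and higher numbers for fast clearance), compound 3 `CCn1c([C@@H](C)NS(=O)(=O)c2ccc(C#N)cc2)nc2ccc(C(F)(F)F)cc21` gives 34 mL.min-1.g-1, the only exact number measured so far. Compound 1 `CCn1c([C@@H](C)NS(=O)(=O)c2ccc(Cl)cc2)nc2ccc(C(F)(F)F)cc21` reads > 100 mL.min-1.g-1, which is a limit of the assay and not a number. Compound 2 `CCn1c([C@@H](C)NS(=O)(=O)C2CC2)nc2ccc(C(F)(F)F)cc21` reads < 3 mL.min-1.g-1, which is also a limit.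

Compound 4 `CCn1c([C@@H](C)NS(=O)(=O)c2cn(C)nc2C)nc2ccc(C(F)(F)F)cc21` is still unmeasured. It has 1,3-dimethyl-1H-pyrazol-4-yl in place of 4-cyanophenyl on a sulfonyl sulfur.

Within the data shown here, three measured steps bear on this change, all at that same sulfonyl sulfur. The first is large, an at least 33-fold lower number from compound 1 to compound 2 (1.52 log units; beyond the scatter). The second is also large, an at least 11-fold higher number from compound 2 to compound 3 (1.05 log units; beyond the scatter). The third is at least modest, an at least 2.9-fold lower number from compound 1 to compound 3 (0.46 log units; beyond the scatter). Compound 1 and compound 3 both carry a six-membered aromatic ring of carbon only there, and both read higher than compound 2, which has cyclopropyl. Compound 4 also lacks that ring, so a fall toward slower clearance seems likely, though a five-membered aromatic ring is no cyclopropyl.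

The expected change is a 4.3-fold lower number from compound 3 to compound 4 (0.63 log units; beyond the scatter). The estimated value for compound 4 is 8 mL.min-1.g-1, with an expected range from 3 mL.min-1.g-1 to 25 mL.min-1.g-1.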

Compound 4, intrinsic clearance in microsomes: 28 mL.min-1.g-1
Estimate against measurement, compound 4: 3.5-fold (0.54 log units) below; measured number above the stated range.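

In this assay, the six-membered aromatic ring of carbon only can give way to a five-membered aromatic ring with 2 hetero atoms with no change beyond the scatter, a 1.2-fold lower number from compound 3 to compound 4 (0.08 log units; within the scatter), so losing that carbon-only ring does not by itself bring the reading down. The gap to the cyclopropyl compound stays wide, an at least 9.3-fold higher number from compound 2 to compound 4 (0.97 log units; beyond the scatter), and this step rests on a limit of the assay: the limit of < 3 mL.min-1.g-1 in this assay, at which 1 of the 4 values shown sits. On these data alone, the step on the other side, an at least 3.5-fold lower number from compound 1 to compound 4 (0.55 log units; beyond the scatter), also rests on a limit of the assay, so its true size stays unknown: the limit of > 100 mL.min-1.g-1 in this assay, at which 1 of the 4 values shown sits.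

As far as these compounds go, whether a methyl or a cyclobutyl group on the sulfonyl sulfur would read with the cyclopropyl compound or with the aromatic ones remains open. So does the part played by the two methyl groups of 1,3-dimethyl-1H-pyrazol-4-yl.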